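This account rests on a few compounds, and the source may have more. Where it says the series, first, only, none or still open, it means among the compounds named here.

In a physicochemical assay for lipophilicity, at pH 7.4 (a higher number here means a more lipophilic compound, a lower number a more polar compound), compound 1 `CNC(=O)c1cc(C)n(Cc2cc(Cl)ccc2OCc2ccccc2)n1` gives > 3.7, which is a limit and not a number. From the compounds shown here alone, compound 2 `Cc1cc(C(=O)Nc2ccccc2)nn1Cc1cc(Cl)ccc1OCc1ccccc1` gives > 3.7, also a limit, so its true position is unknown. This leaves (the limit of > 3.7 in this assay, at which 2 of the 2 values shown sit).

Compound 3 `Cc1cc(C(=O)NCc2ccccc2)nn1Cc1cc(Cl)ccc1OCc1ccccc1` is the next compound, with benzyl in place of phenyl on an amide-type nitrogen. For the measured compounds named here, the one measured step that bears on this change is a step that the two limits leave unreadable from compound 1 to compound 2, where phenyl replaces methyl at the same kind of nitrogen. It offers no size or direction to carry over. With so little to go on, no step beyond the usual scatter is expected, and the estimated step is a step that the limit leaves unreadable from compound 2 to compound 3. A further report as a limit would be no surprise. The estimated value for compound 3 is 4, with an expected range from 3.7 to 4.6.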

Compound 3, distribution coefficient: > 3.7
Compound 3 ended at the assay's limit; the forecaster's own chance of this, stated with the estimate: 85%; the middle value lies beyond the limit too.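

No step can be read between compound 1, compound 2 and compound 3, since all three report only a limit and not a number in this assay: the limit of > 3.7 in this assay, at which 3 of the 3 values shown sit.

The compounds shown leave open where each true value lies, and whether methyl, phenyl or benzyl on the amide-type nitrogen shifts it at all.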